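This account rests on a few compounds, and the source may have more. Where it says the series, first, only, none or still open, it means among the compounds named here.

Compound 3 `CC(=O)OCCOCN1c2ccccc2C(=O)N(Cc2ccccc2)S1(=O)=O` is the only one of the three measured compounds that gives an actual number in a functional assay on HEL cells (Homo sapiens); a higher number here means that more compound is tolerated, a lower number that less compound is tolerated; compound 3 gives 100 ug/mL. Compound 1 `O=C1c2ccccc2N(COCc2ccccc2)S(=O)(=O)N1Cc1ccccc1` gives in this assay only a limit of the assay, > 50 ug/mL. Compound 2 `O=C1c2ccccc2NS(=O)(=O)N1Cc1ccccc1` likewise gives only a limit of the assay there, > 50 ug/mL. Because of the limit of > 50 ug/mL in this assay, at which 2 of the 3 values shown sit, none of the steps among these three compounds can be sized: the step that the two limits leave unreadable from compound 1 to compound 2, the step that the limit leaves unreadable from compound 1 to compound 3 and the step that the limit leaves unreadable from compound 2 to compound 3 all stay unreadable. Compound 4 `C#CCOCN1c2ccccc2C(=O)N(Cc2ccccc2)S1(=O)=O` differs from compound 3 in one place: ethynyl in place of acetoxymethyl on a saturated chain carbon bound to an oxygen on a saturated carbon. Going by the values given here, the step that the limit leaves unreadable from compound 1 to compound 3 changes the same place, but its size cannot be read, so no measured step gives a direction or a size for this change, and the shared core and the benzyl group stay as they are. The expected step of a 1.1-fold lower number from compound 3 to compound 4 (0.05 log units; within the scatter) is therefore none beyond the scatter. Compound 4 is expected to give in this assay about 90 ug/mL, within a range from 35 ug/mL to 200 ug/mL, with a fair chance that only a limit is reported again.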

Compound 4, half-maximal cytotoxic concentration: > 50 ug/mL
Compound 4 gave a limit, no number; the forecaster's own chance of this, stated with the estimate: 50%; the middle value does not contradict the limit.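

Compound 4 gives in this assay only a limit, > 50 ug/mL. Its steps to compound 1, compound 2 and compound 3 therefore cannot be read, for one shared reason: the limit of > 50 ug/mL in this assay, at which 3 of the 4 values shown sit. The compounds shown leave open whether any of these changes on the shared core alters how much compound the cells tolerate, and in which direction.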